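A few compounds are considered here, and "the series" means these few. Any claim that something is new, unique, unknown or untested is made for them only; others in the source may bear on it.

Compound 1, `C=C1C[C@]23C[C@@]1(O)CC[C@@H]2c1cccc(C)c1[C@@H]3Cn1cc(-c2ccc(OC)cc2)nn1`: in a functional assay on SMMC-7721 cells (Homo sapiens) for cytotoxicity, read by MTT assay, with a stated time of 4 days (a higher number here means a weaker inhibitor, a lower number a stronger inhibitor), compound 1 gives > 20000 nM, which is a limit of the assay and not a number.
Compound 2, `C=C1C[C@]23C[C@@]1(O)CC[C@@H]2c1cccc(C)c1[C@@H]3Cn1cc(-c2ccc(Br)cc2)nn1`: in this assay compound 2 gives > 20000 nM, again a limit rather than a number.
Compound 3, `C=C1C(=O)[C@]23C[C@@]1(O)CC[C@H]2c1ccc(O)c(C)c1[C@@H]3Cn1cc(-c2ccc(OC)cc2)nn1`: in this assay compound 3 gives 860 nM.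

Compounds 1 and 2 share one core and differ in a single place: bromo in place of methoxy on an aromatic carbon. The step that the two limits leave unreadable from compound 1 to compound 2 cannot be sized, because the limit of > 20000 nM in this assay, at which 2 of the 3 values shown sit, holds both of the values that would be compared.

Compound 3 stands on a different core; the difference between the two cores is not broken down here. Compound 4, `C=C1C(=O)[C@]23C[C@@]1(O)CC[C@H]2c1ccc(O)c(C)c1[C@@H]3Cn1cc(-c2ccc(Br)cc2)nn1`, has not yet been measured. For the measured compounds named here, it differs from compound 3 by bromo in place of methoxy on an aromatic carbon, the same change as the one from compound 1 to compound 2, at the same kind of place.

Going by the values given here, since the only earlier example of this change is unreadable, the expectation for compound 4 rests on compound 3 at 860 nM and carries a wide allowance. Compound 4 is expected to give 1500 nM, somewhere between 400 nM and 6000 nM. The expected step is a 1.7-fold higher number from compound 3 to compound 4 (0.24 log units; within the scatter).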

Compound 4, half-maximal inhibitory concentration: 1300 nM
For compound 4 the middle estimate is 1.2-fold (0.06 log units) above the measured one; measured number inside the range.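

Where the number can be read, bromo in place of methoxy gives a 1.5-fold higher number from compound 3 to compound 4 (0.18 log units; within the scatter) in this assay, so the two compounds cannot be told apart in this test. The same change on the other core gives no reading, because compound 1 and compound 2 both sit at a limit of the assay rather than at a number: the limit of > 20000 nM in this assay, at which 2 of the 4 values shown sit. This leaves one readable example of the change, which shows that swapping 4-methoxyphenyl for 4-bromophenyl makes no difference beyond the scatter on one core, but does not show that the change behaves the same way on both cores.

The compounds shown carry only methoxy or bromo in this place on the aromatic ring, so it remains open what an amine, a carboxylic acid or a longer chain such as butoxy would do there. They also leave unresolved which part of the difference between the two cores matters for the values in this assay.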